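Imidazolyl for ureido on the sulfur chain

The compounds below may be only part of what the source reports. "The series", "measured", "known", "first", "only" and "open" are said of these compounds alone.

In a functional assay on HT cells (Homo sapiens) for antiproliferative activity, read by fluorescence, with a stated time of 72 h (on this read-out lower numbers stand for stronger inhibition of growth and higher numbers for weaker inhibition of growth), compound 1 `CC(C)c1n[nH]c2c(NCc3ccc(-c4ccccn4)cc3)nc(SC(C)C(C)O)nc12` gives 190 nM and compound 2 `CC(C)c1n[nH]c2c(NCc3ccc(-c4ccccn4)cc3)nc(SCCNC(N)=O)nc12` gives 240 nM so the two stand level. Compound 3 `CC(C)c1n[nH]c2c(NCc3ccc(-c4ccccn4)cc3)nc(SCCn3ccnc3)nc12` differs from compound 2 by 1H-imidazol-1-yl in place of ureido on a saturated chain carbon, two bonds along the chain from a sulfur with 1H-imidazol-1-yl in place of ureido on a saturated chain carbon, two bonds along the chain from a sulfur. Going by the values given here, the only measured step of a 1.3-fold higher number from compound 1 to compound 2 (0.10 log units; within the scatter) also changed the group on the sulfur and stayed within the scatter. On that single precedent, no step beyond the scatter is expected in this assay and the estimated step of a 1.0-fold lower number from compound 2 to compound 3 (0.02 log units; within the scatter) has no firm direction. Compound 3 is expected at 230 nM (estimated range 90 nM to 600 nM).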

Compound 3, concentration for 50% growth inhibition: 155 nM
Compound 3: middle estimate off by 1.5-fold (0.17 log units), on the high side; measured number inside the range.
By their numbers in this assay, from the lowest: compounds 3, 1 and 2 (each within the scatter of the next).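

In this assay, 1H-imidazol-1-yl can replace ureido on this saturated chain carbon, with a 1.5-fold lower number from compound 2 to compound 3 (0.19 log units; within the scatter), so losing the ureido hydrogen-bond donors brings no step beyond the scatter. The 2-(1H-imidazol-1-yl)ethyl group on the sulfur also stands level with 2-hydroxy-1-methylpropyl, with a 1.2-fold lower number from compound 1 to compound 3 (0.09 log units; within the scatter), so an aromatic ring joins the groups tolerated here. No evidence bears on why these groups read alike.

On these data alone, whether an amine, a carboxylic acid or a longer chain on the sulfur would stay level remains open. So far, no group on this sulfur has moved the number beyond the scatter.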